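The source may report more compounds than this note shows. Statements on the series, on what has been measured and on what is new or still open speak of the compounds shown alone.

Compound 1 `Cc1cc(O)c(C(C)C)cc1-c1cc(-c2cccs2)c(C#N)c(=O)[nH]1` is the reference point of this account. Within the data shown here, in a functional assay for inhibition, tested at 40 ug/mL (on this read-out lower numbers stand for a weaker effect and higher numbers for a stronger effect at the one concentration tested), compound 1 gives 41%, the second highest of the three numbers measured so far. Its nearest neighbour is compound 2 `COc1cc(-c2cc(-c3cc(C(C)C)c(O)cc3C)[nH]c(=O)c2C#N)ccc1O`, which gives 32%, and the furthest is compound 3 `COc1cc(OC)c(-c2cc(-c3cc(C(C)C)c(O)cc3C)[nH]c(=O)c2C#N)c(OC)c1`, which gives 52.6%, a number beyond the scatter above compound 1. The step of a number 9 percentage points lower from compound 1 to compound 2 (within the scatter) stays within the scatter.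

Compound 4 `COc1ccc(-c2cc(-c3cc(C(C)C)c(O)cc3C)[nH]c(=O)c2C#N)cc1OC` has not yet been measured. It differs from compound 1 in one place: 3,4-dimethoxyphenyl in place of thiophen-2-yl on an aromatic carbon. Among the measured compounds shown here, the one measured step that bears on this change is a number 9 percentage points lower from compound 1 to compound 2 (within the scatter), which also replaced thiophen-2-yl by a methoxy-bearing phenyl ring and did not move beyond the scatter. Compound 3, whose ring in that place likewise carries methoxy groups, shows a higher number than compound 1, but the pair is not a computed step here. Compound 4 is therefore expected to give 44% in this assay, within a range from 30% to 58%. The expected step of a number 3 percentage points higher from compound 1 to compound 4 (within the scatter) is estimated to remain within the scatter.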

Compound 4, a percentage reported as inhibition, at one concentration (the size of the read-out at that concentration, not a potency): 44%
Estimate against measurement, compound 4: no gap at the digits printed, within the range that was stated.
By their numbers in this assay, from the lowest: compounds 2, 1, 4 and 3 (each within the scatter of the next, the first and the last beyond it).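

Replacing thiophen-2-yl with 3,4-dimethoxyphenyl at this position, opposite the ring nitrogen, brings in a group with more heavy atoms, yet this assay shows only a number 3 percentage points higher from compound 1 to compound 4 (within the scatter) and no shift beyond the scatter. The new information lies on the phenyl ring itself: methyl in place of hydrogen on an oxygen gives a number 12 percentage points higher from compound 2 to compound 4 (beyond the scatter) as a modest step, so a small change on this ring can register even though neither step from compound 1 to these phenyl compounds does. Nothing available bears on the reason for either step.

On these data alone, whether a longer chain such as ethyl on that oxygen would extend or lose this difference remains open. So does the outcome of placing an amine or a carboxylic acid on this ring.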